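The source may hold more compounds than are shown below. What is called first, only, known or untested is meant among the compounds shown, and "the series" means these compounds.

Compound 1 `Nc1ncnc2c1c(-c1cc3ccccc3o1)cn2[C@H]1CCN(C[C@H]2CO2)C1` gives 630 nM.
Compound 2 `Nc1ncnc2c1c(-c1ccc(Oc3ccccc3)cc1)cn2[C@H]1CCN(C[C@H]2CO2)C1` gives 5080 nM.
Compound 3 `Nc1ncnc2c1c(-c1cnc3[nH]ccc3c1)cn2C[C@H]1CCCN1C[C@@H]1CO1` gives "not determined" (no result reported).

These compounds share a common core and were tested in a functional assay on JeKo-1 cells (Homo sapiens) for antiproliferative activity (a higher number here means a weaker inhibitor, a lower number a stronger inhibitor), which measures how strongly each one slows the growth of the cells. Compound 2 stands at the highest of the two numbers available: compound 1 gives the lower number, and the gap between the two lies beyond the usual scatter of repeated measurements. Compound 3 has no result in this assay, so it gives no guidance.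

Compound 4 `Nc1ncnc2c1c(-c1ccc(Oc3ccccc3)cc1)cn2C[C@H]1CCCN1C[C@@H](O)CO` has not yet been measured. It differs from compound 2 at the aromatic nitrogen that bears the large group: (1-(2,3-dihydroxypropyl)pyrrolidin-2-yl)methyl in place of 1-((oxiran-2-yl)methyl)pyrrolidin-3-yl on an aromatic nitrogen. Within the data shown here, no measured pair shows this exact change, so its effect cannot be read off from the numbers already in hand. The expected step is a 2.4-fold higher number from compound 2 to compound 4 (0.37 log units; beyond the scatter), towards a higher number, that is a weaker inhibitor, and larger than the scatter. Compound 4 is estimated to give 12000 nM in this assay, with a likely range from 4000 nM to 40000 nM.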

Compound 4, half-maximal inhibitory concentration: 9540 nM
Compound 4: the middle estimate sits 1.3-fold (0.10 log units) above what was measured; the range from low to high includes it.
By their numbers in this assay, from the lowest: compound 1; then compounds 2 and 4 (each within the scatter of the next).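

In this assay, placing (1-(2,3-dihydroxypropyl)pyrrolidin-2-yl)methyl in place of 1-((oxiran-2-yl)methyl)pyrrolidin-3-yl on the aromatic nitrogen gives a 1.9-fold higher number from compound 2 to compound 4 (0.27 log units; within the scatter). Among these compounds, this is the first reading of a change at this position: the three-membered ring leaves and hydrogen-bond donors enter, yet the two compounds cannot be told apart in this measurement. Nothing measured here offers a reason for this outcome.

The change alters the ring attachment and the chain end together, so the compounds shown do not separate the contribution of each part, and they leave open how the same large group would behave with the aromatic group of compound 1. Also open, going by these compounds, is whether a carboxylic acid or a primary amine at the chain end, in place of the two hydroxyl groups, would give a similar number.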